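A few compounds are considered here, and "the series" means these few. Any claim that something is new, unique, unknown or untested is made for them only; others in the source may bear on it.

Measured so far, in an assay on isolated protein for inhibition of Rho-associated protein kinase 2 (Homo sapiens), read by scintillation counting, radiometric assay and 33P incorporation, with a stated time of 40 min, in the presence of a further agent that is not named here; a higher number here means a weaker inhibitor, a lower number a stronger inhibitor:
compound 1 `COc1cccc(OCC(=O)Nc2cccc(NC(=O)c3ccc(N(C)C)cc3)c2)c1` — 5740 nM
compound 2 `COc1ccc(OCC(=O)Nc2cccc(NC(=O)c3ccc(N(C)C)cc3)c2)cc1OC` — > 10000 nM

Compound 2 stands at the ceiling of the range: in this assay compound 2 gives > 10000 nM, which is a limit of the assay rather than a number (the limit of > 10000 nM in this assay, at which 1 of the 2 values shown sits). Compound 1 is the only measured partner with a number. Compound 3 `COc1ccc(OCC(=O)Nc2cccc(NC(=O)c3ccc(N(C)C)cc3)c2)cc1F` differs from compound 2 by fluoro in place of methoxy on an aromatic carbon, in words fluoro in place of methoxy on an aromatic carbon. Within the data shown here, the one measured step at this position is an at least 1.7-fold higher number from compound 1 to compound 2 (0.24 log units; that floor lies within the scatter), where methoxy entered in place of hydrogen. The move to fluoro leaves a substituent at that carbon, so the expected step of an at least 1.1-fold lower number from compound 2 to compound 3 (0.07 log units; that floor lies within the scatter) is small, within the scatter, with the number most likely still near the limit. Compound 3 is therefore expected at 8500 nM, with a range from 4000 nM to 20000 nM.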

Compound 3, half-maximal inhibitory concentration: 652 nM
Compound 3: the middle estimate sits 13-fold (1.12 log units) above what was measured; the whole stated range lies above it.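

In this assay, the identity of the group at this aromatic carbon matters, not merely whether the carbon carries a substituent: fluoro in place of methoxy gives an at least 15-fold lower number from compound 2 to compound 3 (1.18 log units; beyond the scatter). Set against the 3-methoxyphenyl group, 3-fluoro-4-methoxyphenyl gives an 8.8-fold lower number from compound 1 to compound 3 (0.94 log units; beyond the scatter), so this substituted phenyl group also improves on the less substituted one. Compound 2 stands at a limit and not at a number, so the step from it stays a floor: the limit of > 10000 nM in this assay, at which 1 of the 3 values shown sits.

From the compounds shown here alone, whether chloro, methyl or a nitrile at this carbon would match fluoro remains open. Also open, going by these compounds, is whether fluoro would give the same step without the methoxy group it sits ortho to, and whether a hydroxy or an amine in place of that methoxy group would keep the number reached here.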